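Ethoxy to methoxy on a sulfonylurea-type chain

A few compounds are considered here, and "the series" means these few. Any claim that something is new, unique, unknown or untested is made for them only; others in the source may bear on it.

Values so far in a functional assay on thoracic aorta (Rattus norvegicus, strain Wistar), with a stated time of 15 min (on this read-out higher numbers stand for an effect only at larger amounts of compound and lower numbers for an effect already at smaller amounts), are:
- Compound 1 (`COc1ccc(Br)cc1C(C)NC(=O)NS(=O)(=O)c1ccc(C)cc1`) gives > 300000 nM
- Compound 2 (`CCOc1ccc(Cl)cc1C(C)NC(=O)N(C)S(=O)(=O)c1ccccc1`) gives 10500 nM
- Compound 3 (`CCOc1ccc(Cl)cc1C(C)NC(=O)N(C)S(=O)(=O)c1ccc(Cl)cc1`) gives 14600 nM

Compound 1 reports only a limit of > 300000 nM and not a number. Compound 3 is the nearest neighbour of compound 2 at 10500 nM and the two lie within the scatter of each other. Compound 4 (`COc1ccc(Cl)cc1C(C)NC(=O)N(C)S(=O)(=O)c1ccccc1`) has hydrogen in place of methyl on a saturated chain carbon bound to an oxygen on an aromatic ring, so ethoxy becomes methoxy (hydrogen in place of methyl on a saturated chain carbon bound to an oxygen on an aromatic ring). Going by the values given here, the only measured step is a 1.4-fold higher number from compound 2 to compound 3 (0.14 log units; within the scatter) and it lies within the scatter, at a different place on the molecule. Among the compounds with values here, no measured step touches this change directly. In this assay the expected step is a 1.1-fold higher number from compound 2 to compound 4 (0.06 log units; within the scatter) and it is estimated to stay within the scatter. Compound 4 is estimated at 12000 nM (expected range 4500 nM to 32000 nM).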

Compound 4, half-maximal effective concentration: 7200 nM
Estimate against measurement, compound 4: 1.7-fold (0.22 log units) above; low and high end bracket the measured number.
By their numbers in this assay, from the lowest: compounds 4, 2 and 3 (each within the scatter of the next, the first and the last beyond it). At a limit, above all of these: compound 1.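

In this assay, going by these compounds alone, ethoxy to methoxy gives a 1.5-fold lower number from compound 2 to compound 4 (0.16 log units; within the scatter), the first measured step on a saturated chain carbon bound to an oxygen on an aromatic ring. The earlier step, from chloro in place of hydrogen, was at a different place on the molecule, so this position had no reading of its own until now. Nothing measured here offers a reason for this result.

As far as these compounds go, whether a longer chain such as propoxy would also stay within the scatter remains open. So does the effect of an amine at this place.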